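Replacing the amine nitrogen substituent of compound 2

A few compounds are considered here, and "the series" means these few. Any claim that something is new, unique, unknown or untested is made for them only; others in the source may bear on it.

For the measured compounds named here, compound 2 `C/C=C/C(=O)NCCOc1ccc(Oc2c(-c3ccc(F)cc3)sc3cc(O)ccc23)cc1` gives 12400 nM in a functional assay on Ishikawa cells (Homo sapiens) for antiproliferative activity, read by CCK-8 assay, with a stated time of 48 h (a lower number here means a stronger inhibitor, a higher number a weaker inhibitor), and stands level with the only other measured compound. That is compound 1 `CNC(=O)/C=C/CNCCOc1ccc(Oc2c(-c3ccc(F)cc3)sc3cc(O)ccc23)cc1`, which gives 15500 nM in this assay and carries 3-(methylcarbamoyl)prop-2-en-1-yl on the amine nitrogen. Compound 3 `O=C(/C=C/CNCCOc1ccc(Oc2c(-c3ccc(F)cc3)sc3cc(O)ccc23)cc1)N1CCCCC1` has 3-((piperidin-1-yl)carbonyl)prop-2-en-1-yl in place of (prop-1-en-1-yl)carbonyl on an amine nitrogen. Going by the values given here, the one measured step that bears on this change is a 1.3-fold lower number from compound 1 to compound 2 (0.10 log units; within the scatter) and it concerns the same place on the molecule. Its entering group resembles that of compound 3 in the prop-2-en-1-yl chain, yet the exchange did not move the number beyond the scatter. Among the compounds with values here, no measured compound carries the six-membered non-aromatic ring, so that part of the change is untested and the range must stay wide. The expected step is a 1.0-fold lower number from compound 2 to compound 3 (0.01 log units; within the scatter) and no shift beyond the scatter is anticipated in either direction. Compound 3 is estimated at 12000 nM in this assay with an expected range of 5000 nM to 28000 nM here.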

Compound 3, half-maximal inhibitory concentration: 8430 nM
For compound 3 the middle estimate is 1.4-fold (0.15 log units) above the measured one; measured number inside the range.
By their numbers in this assay, from the lowest: compounds 3, 2 and 1 (each within the scatter of the next).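

The new compound shows that this place on the amine nitrogen accepts the larger 3-((piperidin-1-yl)carbonyl)prop-2-en-1-yl, with its six-membered non-aromatic ring, in place of (prop-1-en-1-yl)carbonyl without a shift beyond the scatter in this assay (a 1.5-fold lower number from compound 2 to compound 3 (0.17 log units; within the scatter)). For the compounds shown here, it also supplies the first reading on the far end of the prop-2-en-1-yl chain, where piperidin-1-yl in place of methylamino on a carbonyl carbon likewise stays within the scatter (a 1.8-fold lower number from compound 1 to compound 3 (0.26 log units; within the scatter)), so the three groups seen so far at this place cannot be told apart in this assay. No measured evidence is available to explain these small differences.

The compounds shown leave open whether a dimethylamino group, a morpholine ring or a carboxylic acid in place of piperidin-1-yl on that carbonyl carbon would move the number beyond the scatter. They also leave open what a longer chain between the amine nitrogen and the carbonyl would do, and whether any change at this place would matter on a different core.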